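This account rests on a few compounds, and the source may have more. Where it says the series, first, only, none or still open, it means among the compounds named here.

Working notes on the series. Compound 1 `Cn1nc2c(=O)n(CC3(O)CCN(Cc4ccc(-n5ccnc5)cc4Cl)CC3)cnc2c1-c1ccc(CN)cc1` gives 228 nM in an assay on isolated protein for inhibition of ubiquitin carboxyl-terminal hydrolase 7 (Homo sapiens), with stated times of 30 min and 2 h; on this read-out higher numbers stand for weaker inhibition and lower numbers for stronger inhibition. Among the measured compounds shown here, compound 2 `Cn1nc2c(=O)n(CC3(O)CCN(Cc4ccc(-c5ccc(C(=O)O)o5)cc4Cl)CC3)cnc2c1-c1ccc(CN)cc1` gives 753 nM in this assay, the higher of the two numbers measured so far; the change a 3.3-fold higher number from compound 1 to compound 2 (0.52 log units; beyond the scatter) is the only step in the set. Compound 3 `Cn1nc2c(=O)n(CC3(O)CCN(Cc4ccc(-c5ccco5)cc4Cl)CC3)cnc2c1-c1ccc(CN)cc1` differs from compound 2 in one place: hydrogen in place of carboxy on an aromatic carbon. For the measured compounds named here, no measured step bears directly on this change; the single step from compound 1 to compound 2 exchanges one five-membered ring for another together with the carboxy, so it separates neither the ring nor the carboxy. The direction of the new step in this assay is therefore open, and a number anywhere around that of compound 2 would not be surprising. For compound 3 in this assay a step of a 1.7-fold lower number from compound 2 to compound 3 (0.22 log units; within the scatter) is estimated, leaning toward a lower number. Compound 3 is expected at 450 nM, within 150 nM to 1400 nM.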

Compound 3, half-maximal inhibitory concentration: 18.1 nM
Compound 3: middle estimate off by 25-fold (1.40 log units), on the high side; measured number below the stated range.
By their numbers in this assay, from the lowest: compound 3; then compound 1; then compound 2.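

On this position, the carboxy next to the ring oxygen carries a large cost in this assay: its replacement by hydrogen gives a 42-fold lower number from compound 2 to compound 3 (1.62 log units; beyond the scatter). The exchange of 1H-imidazol-1-yl for furan-2-yl, which the earlier step could not separate from the carboxy, gives a 13-fold lower number from compound 1 to compound 3 (1.10 log units; beyond the scatter). The earlier step therefore splits into two parts of opposite direction, with the ring exchange alone moving to a lower number and the carboxy moving far enough back to leave compound 2 above compound 1.

From the compounds shown here alone, it remains open whether the cost belongs to the carboxylic acid itself or to any group at this place; a methyl, a methyl ester or an aminomethyl group there would separate the two. Nothing available gives a measured explanation for either step.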